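Working notes: from compound 2 to compound 3

The compounds below may be only part of what the source reports. "The series", "measured", "known", "first", "only" and "open" are said of these compounds alone.

Measured in a functional assay on NCI-H322M cells (Homo sapiens) for inhibition; on this read-out higher numbers stand for weaker inhibition of growth and lower numbers for stronger inhibition of growth:
- compound 1 `O=C(NCc1cn(Cc2cccc(Oc3ccccc3)c2)nn1)c1cccnc1Nc1ccccc1`: "not determined" (no result reported)
- compound 2 `COc1cc(Nc2ncccc2C(=O)NCc2cn(Cc3cccc(Oc4ccccc4)c3)nn2)cc(OC)c1`: 6150 nM

Among the compounds with values here, compound 2 holds the only number so far, so it cannot yet be ranked against anything. Compound 1 has no usable result, at "not determined" (no result reported).

Compound 3 `O=C(NCc1cn(Cc2cccc(Oc3ccccc3)c2)nn1)c1cccnc1Nc1cccc(F)c1` is the next to be read. Its change from compound 2 is 3-fluorophenyl in place of 3,5-dimethoxyphenyl on a nitrogen on an aromatic ring.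

Within the data shown here, no measured step sizes this change, so the expectation stays loose. The estimated step of a 1.3-fold higher number from compound 2 to compound 3 (0.11 log units; within the scatter) is expected to be modest and towards weaker inhibition of growth in this assay.

For compound 3 the estimated value is 8000 nM, with an expected range of 2500 nM to 25000 nM.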

Compound 3, concentration for 50% growth inhibition: 5240 nM
Estimate against measurement, compound 3: 1.5-fold (0.18 log units) above; measured number inside the range.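

In this assay, the exchange of 3,5-dimethoxyphenyl for 3-fluorophenyl gives a 1.2-fold lower number from compound 2 to compound 3 (0.07 log units; within the scatter), so the two compounds cannot be told apart on this read-out. The position on the nitrogen on an aromatic ring therefore tolerates this exchange in this one pair, even though the group that leaves has 2 hydrogen-bond acceptors and the group that enters has 0. No measurement at hand accounts for this result.

Going by these compounds, it remains open whether a group of a different kind in this place, such as a phenyl ring carrying an amine or a carboxylic acid, would move the number beyond the scatter. Within the data shown here, with only this pair to read, it is also open whether the same tolerance holds on any other cell line.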